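Ethoxy in Place of Chloro on Compound 1

The source may report more compounds than this note shows. Statements on the series, on what has been measured and on what is new or still open speak of the compounds shown alone.

Compound 1 `CC1CC/C(=N\Nc2cccc(Cl)c2)c2ncc(C(=O)O)c(=O)n21` was tested in a functional assay on the whole organism for inhibition, with Rattus norvegicus as the target (on this read-out lower numbers stand for an effect already at smaller amounts and higher numbers for an effect only at larger amounts of compound), where compound 1 gives 0.6 umol/kg. Among the three measured compounds it holds the second highest number: compound 2 `CC1CC/C(=N\Nc2ccc(Cl)cc2)c2ncc(C(=O)O)c(=O)n21` gives 0.5 umol/kg, and a 1.2-fold lower number from compound 1 to compound 2 (0.08 log units; within the scatter); compound 3 `CC1CC/C(=N\Nc2ccc(O)cc2)c2ncc(C(=O)O)c(=O)n21` gives 1.7 umol/kg, and a 2.8-fold higher number from compound 1 to compound 3 (0.45 log units; beyond the scatter). Compound 4 `CCOc1cccc(N/N=C2\CCC(C)n3c2ncc(C(=O)O)c3=O)c1` differs from compound 1 in one place: ethoxy in place of chloro on an aromatic carbon. For the measured compounds named here, no measured step swaps chloro for ethoxy. The nearest guides are a 2.8-fold higher number from compound 1 to compound 3 (0.45 log units; beyond the scatter) and a 3.4-fold higher number from compound 2 to compound 3 (0.53 log units; beyond the scatter), both modest rises when hydroxy replaces chloro, though ethoxy is not hydroxy. A small rise in this assay is therefore expected, a 2.0-fold higher number from compound 1 to compound 4 (0.30 log units; within the scatter). Compound 4 is estimated at 1.2 umol/kg, with a range from 0.5 umol/kg to 3 umol/kg.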

Compound 4, dose for 50% inhibition: 0.2 umol/kg
Estimate against measurement, compound 4: 6.0-fold (0.78 log units) above, outside the stated range (below it).
By their numbers in this assay, from the lowest: compound 4; then compounds 2 and 1 (each within the scatter of the next); then compound 3.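

In this assay, the aromatic carbon meta to a large group carries ethoxy, with three heavy atoms in place of the single chlorine, and the result is a 3.0-fold lower number from compound 1 to compound 4 (0.48 log units; beyond the scatter). An oxygen-linked group here therefore need not raise the number, unlike the hydroxy change in a 2.8-fold higher number from compound 1 to compound 3 (0.45 log units; beyond the scatter), which also sits at a different place on the ring. Nothing available explains this fall. From the compounds shown here alone, whether a shorter methoxy or a longer butoxy group would lower the number further remains open. A propyl chain would show whether the oxygen matters.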